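A few compounds are considered here, and "the series" means these few. Any claim that something is new, unique, unknown or untested is made for them only; others in the source may bear on it.

In a functional assay on HeLa cells (Homo sapiens) for cytotoxicity (on this read-out higher numbers stand for weaker inhibition and lower numbers for stronger inhibition), compound 3 `O=C1C=C(Oc2ccco2)C(=O)c2ccccc21` gives 37000 nM, at the top of the three numbers, with compound 1 `CCOC1=CC(=O)c2ccccc2C1=O` at 23800 nM inside the scatter of it and compound 2 `CS(=O)(=O)OC1=CC(=O)c2ccccc2C1=O` at 7610 nM clearly beyond it. Compound 4 `O=C1C=C(Oc2cccs2)C(=O)c2ccccc21` differs from compound 3 by thiophen-2-yl in place of furan-2-yl on an oxygen on an unsaturated carbon. The two steps that reach compound 3 both change the group on that oxygen: a 1.6-fold higher number from compound 1 to compound 3 (0.19 log units; within the scatter) and a 4.9-fold higher number from compound 2 to compound 3 (0.69 log units; beyond the scatter). For the measured compounds named here, neither swaps one five-membered aromatic ring for another, so no measured step bears directly on the present change, and the step of a 1.1-fold lower number from compound 3 to compound 4 (0.02 log units; within the scatter) is expected to stay within the scatter. Compound 4 is therefore estimated at 35000 nM, within 15000 nM to 80000 nM.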

Compound 4, half-maximal inhibitory concentration: 35300 nM
For compound 4 the middle estimate is 1.0-fold (0.00 log units) below the measured one; low and high end bracket the measured number.
By their numbers in this assay, from the lowest: compound 2; then compounds 1, 4 and 3 (each within the scatter of the next).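

In this assay, for the compounds shown here, thiophen-2-yl and furan-2-yl on this oxygen cannot be told apart (a 1.0-fold lower number from compound 3 to compound 4 (0.02 log units; within the scatter)), the first exchange of one five-membered aromatic ring for another at this position. Thiophen-2-yl also stays within the scatter of ethyl (a 1.5-fold higher number from compound 1 to compound 4 (0.17 log units; within the scatter)), while methylsulfonyl remains set apart (a 4.6-fold higher number from compound 2 to compound 4 (0.67 log units; beyond the scatter)), leaving compound 2 as the only member separated from the other three. No measurement on hand accounts for these steps.

Open, on these data alone, is whether phenyl, a longer chain or a carboxylic acid on this oxygen would stay with the ethyl and ring compounds or move towards compound 2. As far as these compounds go, how far other sulfonyl groups would follow methylsulfonyl is also open.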